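Aryl Swap on the Shared Core: Compound 1 to Compound 4

The source may hold more compounds than are shown below. What is called first, only, known or untested is meant among the compounds shown, and "the series" means these compounds.

In a functional assay on cells (Pituitary gland cell) for antagonist activity at Gonadotropin-releasing hormone receptor (Rattus norvegicus) (on this read-out higher numbers stand for weaker inhibition and lower numbers for stronger inhibition), compound 1 `Cc1cc(-c2c(O)nc3cc(Cl)c([N+](=O)[O-])cc3c2OCCC2CCCCN2)cc(C(C)O)c1` gives 63 nM. Compound 2 `O=[N+]([O-])c1cc2c(OCCC3CCCCN3)c(-c3cc(C(F)(F)F)cc(C(F)(F)F)c3)c(O)nc2cc1Cl` gives 71 nM and compound 3 `O=C(Nc1cc2c(OCCC3CCCCN3)c(-c3cccc(Br)c3)c(O)nc2cc1Cl)NC1CC1` gives 6 nM. Among these three numbers compound 1 stands second highest: its nearest neighbour is compound 2, a gap that falls within the scatter, and its furthest is compound 3, whose lower number lies beyond the scatter. Compound 3 differs from compound 1 in more than one place, so that gap cannot be assigned to any single change.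

Compound 4 `O=[N+]([O-])c1cc2c(OCCC3CCCCN3)c(-c3ccccc3Cl)c(O)nc2cc1Cl` has not been measured. Against compound 1 it differs by 2-chlorophenyl in place of 3-(1-hydroxyethyl)-5-methylphenyl on an aromatic carbon. Going by the values given here, no measured pair differs in exactly this way, so no step of this kind is known. What can be read is that compound 1 and compound 2, carrying two rather different aryl groups on the same aromatic carbon of the shared core, give numbers within the scatter of each other; compound 3 cannot be used as a comparison here. The step from compound 1 to compound 4 is therefore expected to be small, at most a modest weakening, as a 1.6-fold higher number from compound 1 to compound 4 (0.20 log units; within the scatter). Compound 4 is estimated at 100 nM in this assay, with a range from 25 nM to 400 nM.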

Compound 4, half-maximal inhibitory concentration: 360 nM
Beside the measured number, compound 4's estimate is 3.6-fold (0.56 log units) below it, within the range that was stated.
By their numbers in this assay, from the lowest: compound 3; then compounds 1 and 2 (each within the scatter of the next); then compound 4.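

In this assay, this aromatic carbon of the shared core proves sensitive to the group it carries: 2-chlorophenyl in place of 3-(1-hydroxyethyl)-5-methylphenyl gives a 5.7-fold higher number from compound 1 to compound 4 (0.76 log units; beyond the scatter), a step that the closeness of compound 1 and compound 2 did not reveal. Compound 2, which has no 1-hydroxyethyl group, gives 71 nM, within the scatter of compound 1, so a number of this size does not require that group; the swap to compound 4 also changes the substitution pattern and brings in chlorine, and this single step cannot separate those changes. Nothing available explains the step.

Still open, on these data alone, is whether the chlorine itself or its location on the phenyl ring goes with the higher number, a question that 3-chlorophenyl, 4-chlorophenyl and unsubstituted phenyl on the same core would address. Also open, as far as these compounds go, is whether the same aryl groups would rank the same way with the cyclopropyl urea of compound 3 in place of the nitro group.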